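From a 3-methylphenyl group to a benzimidazole

The source may report more compounds than this note shows. Statements on the series, on what has been measured and on what is new or still open speak of the compounds shown alone.

Of the compounds shown here, three sharing one core have been measured in a physicochemical assay for solubility; a lower number here means a less soluble compound, a higher number a more soluble compound: compound 1 `CNC(=O)c1cc(C(=O)NC2CC2)cn(Cc2ccc(F)cc2)c1=O`, compound 2 `CNC(=O)c1cc(C(=O)NC2CC2)cn(Cc2nccc3[nH]ccc23)c1=O` and compound 3 `CNC(=O)c1cc(C(=O)NC2CC2)cn(Cc2cccc(C)c2)c1=O`. Compound 3 gives >= 205 ug/mL, which is a limit of the assay and not a number. Compound 1 gives >= 162 ug/mL, which is also a limit. For the measured compounds named here, compound 2 gives 73 ug/mL, the only actual number among the three.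

Compound 4 `CNC(=O)c1cc(C(=O)NC2CC2)cn(Cc2ccc3nc[nH]c3c2)c1=O` is still unmeasured. It differs from compound 3 in one place, on a saturated chain carbon bound to an aromatic nitrogen: 1H-benzimidazol-6-yl in place of 3-methylphenyl on a saturated chain carbon bound to an aromatic nitrogen.

The nearest guide is the group in compound 2, which has the same atom tally as the entering 1H-benzimidazol-6-yl, though its rings differ. Two measured steps involve that group: an at least 2.2-fold lower number from compound 1 to compound 2 (0.34 log units; beyond the scatter), and an at least 2.8-fold higher number from compound 2 to compound 3 (0.44 log units; beyond the scatter). Both lie beyond the scatter, and both put the group of compound 2 on the lower side. The remaining step, a step that the two limits leave unreadable from compound 1 to compound 3, adds nothing on size. In this assay a drop of at least modest size is therefore expected on leaving compound 3, as the step of an at least 2.8-fold higher number from compound 2 to compound 3 (0.44 log units; beyond the scatter) suggests when read in reverse.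

The estimated change is an at least 2.1-fold lower number from compound 3 to compound 4 (0.33 log units; beyond the scatter). For compound 4 the expected value is 95 ug/mL, with an estimated range of 35 ug/mL to 220 ug/mL.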

Compound 4, solubility: >= 163 ug/mL
Compound 4: a limit, no number (the forecaster's own chance of this, stated with the estimate: 20%); at least 1.7-fold (0.23 log units) between middle value and limit.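

In this assay compound 4 gives >= 163 ug/mL, which is a limit of the assay and not a number. For the compounds shown here, the one new step that can be read is an at least 2.2-fold higher number from compound 2 to compound 4 (0.34 log units; beyond the scatter). It joins two groups with the same atom tally on a saturated chain carbon bound to an aromatic nitrogen, though their rings differ, so at this position the tally alone does not fix the read-out. The other two new steps cannot be read, because both ends of each are limits: the limit of >= 163 ug/mL in this assay, at which 1 of the 4 values shown sits.

With three of the four compounds at limits, the compounds shown leave open how far 1H-benzimidazol-6-yl, 3-methylphenyl and 4-fluorophenyl actually stand apart in this assay. Also open, going by these compounds, is where a group carrying an amine or a carboxylic acid would fall on a saturated chain carbon bound to an aromatic nitrogen, and whether such a group would give a number or another limit.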